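The source may hold more compounds than are shown below. What is called first, only, known or untested is meant among the compounds shown, and "the series" means these compounds.

Measured so far:
- Compound 1 `CCOC(=O)c1cccc(-c2ccc(OCC)cc2)n1`: 60000 nM
- Compound 2 `CCOC(=O)c1cncc(-c2ccc(OCC)cc2)c1`: 130000 nM
- Compound 3 `CCOC(=O)c1cccc(-c2ccc(O)cc2)c1`: 100000 nM

All three numbers come from an assay on COS-7 cells for inhibition of patatin-like phospholipase domain-containing protein 2 (Mus musculus) (a lower number here means a stronger inhibitor, a higher number a weaker inhibitor), and all sit in the weak range. Compound 3 gives 100000 nM in this assay, the second highest of the three numbers. Its nearest neighbour is compound 2 at 130000 nM, within the scatter of repeated measurement, and its furthest is compound 1 at 60000 nM, also within the scatter. For the measured compounds named here, on these numbers no compound can be called stronger or weaker than another, and no step between any two of them is set out.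

Compound 4 `CCOC(=O)c1cccc(-c2ccc(CN3CCCCC3)cc2)c1` has not been measured in this assay. It differs from compound 3 in one place: (piperidin-1-yl)methyl in place of hydroxy on an aromatic carbon. The exchange sits on the ring of carbon only, para to a large group, and puts a (piperidin-1-yl)methyl where compound 3 carries a hydroxy.

Going by the values given here, there is no measured step of this kind to lean on. Compound 3 gives a high number at 100000 nM, so a move to lower numbers is expected rather than a move further up. The expected step from compound 3 to compound 4 in this assay is a 2.5-fold lower number from compound 3 to compound 4 (0.40 log units; beyond the scatter), a moderate drop that may still lie close to the scatter. For compound 4 the estimate in this assay is 40000 nM, with a range from 8000 nM to 200000 nM.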

Compound 4, half-maximal inhibitory concentration: 75000 nM
The estimate for compound 4 lay 1.9-fold (0.27 log units) below the measured number; low and high end bracket the measured number.
By their numbers in this assay, from the lowest: compounds 1, 4, 3 and 2 (each within the scatter of the next, the first and the last beyond it).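

In this assay, for the compounds shown here, the step of a 1.3-fold lower number from compound 3 to compound 4 (0.12 log units; within the scatter) is the first single-place comparison, and it lies within the scatter. At this position, on the ring of carbon only and para to a large group, hydroxy and (piperidin-1-yl)methyl therefore cannot be told apart, although the change replaces 1 heavy atom with 7, adds a six-membered non-aromatic ring and removes the hydrogen-bond donor. So this much added bulk at this position leaves the number in the same weak range, and no measurement at hand explains the result.

Open, going by these compounds, is whether any group at this position can move the number beyond the scatter, for instance a carboxylic acid, a primary amine or a longer chain ending in a morpholine ring. Equally open, on these data alone, is how much the ethyl ester contributes to the weak values of the series, a question that a carboxylic acid or a primary amide in its place would address.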